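Trimming a Benzyl Group Down to Methyl

The compounds below may be only part of what the source reports. "The series", "measured", "known", "first", "only" and "open" are said of these compounds alone.

In a functional assay on LNCaP cells (Homo sapiens) for cytotoxicity, read by MTT assay (on this read-out higher numbers stand for weaker inhibition and lower numbers for stronger inhibition), compound 1 `c1ccc(Cc2nnc(-c3c[nH]c4ccccc34)o2)cc1` is recorded only as a limit, > 1000000 nM. The same holds for compound 2 `COc1cc(-c2nnc(-c3c[nH]c4ccccc34)o2)ccc1OCc1ccccc1`, whose value in this assay is likewise a limit, > 1000000 nM. Both sit at the limit of > 1000000 nM in this assay, at which 2 of the 2 values shown sit, so compound 1 stands together with compound 2 at the edge of what this assay can report. Compound 3 `Cc1nnc(-c2c[nH]c3ccccc23)o1` differs from compound 1 by hydrogen in place of phenyl on a saturated chain carbon bound to an aromatic carbon. No change beyond the scatter is expected, and the estimated step reads a number no higher from compound 1 to compound 3 (the limit leaves the size open). Compound 3 is expected to give 1000000 nM in this assay, within 300000 nM to 3000000 nM, most likely again as a limit.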

Compound 3, half-maximal inhibitory concentration: > 1000000 nM
Compound 3: only a limit was reported; the forecaster's own chance of this, stated with the estimate: 85%; the middle value lies on the limit itself.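

Among these compounds, compound 1 and compound 3 are both recorded only as limits, so no step between them can be read: the limit of > 1000000 nM in this assay, at which 3 of the 3 values shown sit. The compounds shown leave open whether benzyl to methyl changes anything in this assay.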